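Phenyl in place of cyano: working notes on the series

The compounds below may be only part of what the source reports. "The series", "measured", "known", "first", "only" and "open" are said of these compounds alone.

Measured in an ADME assay on HCT-116 cells (Homo sapiens) for cytotoxicity, read by CellTiter-Glo, with a stated time of 72 h; a lower number here means a stronger inhibitor, a higher number a weaker inhibitor:
- compound 1 `CC1CCN(C2CCN(S(=O)(=O)c3ccc(C#N)cc3)CC2)CC1`: > 5000 nM
- compound 2 `CC1CCN(C2CCN(S(=O)(=O)c3nccn3C)CC2)CC1`: > 10000 nM
- compound 3 `CC1CCN(C2CCN(S(=O)(=O)c3ccc(Cl)nc3)CC2)CC1`: > 10000 nM

All three entries are limits, not numbers. Compound 1 stands at the limit of > 5000 nM in this assay, at which 1 of the 3 values shown sits. Compound 2 and compound 3 stand at the limit of > 10000 nM in this assay, at which 2 of the 3 values shown sit. Going by the values given here, no measured compound therefore has a numerical value to anchor the comparison.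

Compound 4 `CC1CCN(C2CCN(S(=O)(=O)c3ccc(-c4ccccc4)cc3)CC2)CC1` keeps the rest of compound 1 and carries phenyl in place of cyano on an aromatic carbon, para to a large group: phenyl in place of cyano on an aromatic carbon.

Among the compounds with values here, three measured steps bear on this change, all of them exchanges of the group on the sulfonyl sulfur: a step that the two limits leave unreadable from compound 1 to compound 2, a step that the two limits leave unreadable from compound 1 to compound 3 and a step that the two limits leave unreadable from compound 2 to compound 3. None of these has a readable size, and none places phenyl on the aromatic ring, so no step beyond the scatter is expected in this assay. Compound 4 is expected to remain weak, and a further limit is the likeliest result. The estimated step is a step that the limit leaves unreadable from compound 1 to compound 4. For compound 4 the estimated value is 10000 nM, with an expected range of 3000 nM to 30000 nM.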

Compound 4, half-maximal inhibitory concentration: > 5000 nM
Compound 4: only a limit was reported (the forecaster's own chance of this, stated with the estimate: 75%); the middle value does not contradict the limit.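

The step from compound 1 to compound 4 cannot be read, as both entries in this assay are limits and not numbers. The compounds shown leave open how large any step for phenyl in place of cyano is, and where any compound in the series would fall on a numerical scale in this assay.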